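Allyloxy in Place of Cyclopropylamino: Cytotoxicity Outlook

The source may hold more compounds than are shown below. What is called first, only, known or untested is meant among the compounds shown, and "the series" means these compounds.

Compound 1, `Nc1nc(NC2CC2)c2ncn(/C=C3/CC3(CO)CO)c2n1`, in an ADME assay on MOLT-3 cells (Homo sapiens) for cytotoxicity, with a stated time of 7 days (on this read-out higher numbers stand for lower toxicity in this test and lower numbers for higher toxicity in this test), gives only a limit of the test, > 20000 nM.
Compound 2, `CCCNc1nc(N)nc2c1ncn2/C=C1/CC1(CO)CO`, in this assay gives "not determined" (no result reported).
Compound 3, `CCCCCCOc1nc(N)nc2c1ncn2/C=C1/CC1(CO)CO`, in this assay gives only a limit of the test, > 20000 nM.

Compound 1 thus stands at the edge of what this assay can report: no number is known for it, only a limit. Within the data shown here, the single measured step that can be compared, a step that the two limits leave unreadable from compound 1 to compound 3, is unreadable since both of its ends are the limit of > 20000 nM in this assay, at which 2 of the 3 values shown sit. Compound 2 contributes no result at all, so nothing on the shared core can be ranked.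

The compound still to be tested is compound 4, `C=CCOc1nc(N)nc2c1ncn2/C=C1/CC1(CO)CO`. Its change from compound 1 is allyloxy in place of cyclopropylamino on an aromatic carbon. Among the measured compounds shown here, the only comparable step, the exchange of cyclopropylamino for hexyloxy, left the read-out at its limit, and the exchange for allyloxy is of the same kind. Compound 4 is therefore expected to stay at the limit too, with an estimated 30000 nM spanning 15000 nM to 100000 nM. The expected step that the limit leaves unreadable from compound 1 to compound 4 is thus estimated to show no change beyond the scatter of this assay.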

Compound 4, half-maximal cytotoxic concentration: > 20000 nM
Compound 4: no number, only a limit; the forecaster's own chance of this, stated with the estimate: 80%; the middle value is on the limit's open side.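

Compound 1, compound 3 and compound 4 each give only a limit rather than a number in this assay, so no step among them can be read: the limit of > 20000 nM in this assay, at which 3 of the 4 values shown sit.

The compounds shown leave open whether exchanging cyclopropylamino for allyloxy or hexyloxy changes the cytotoxicity at all.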